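Chain lengthening in the bromophenoxy imidazolidinone series

The source may report more compounds than this note shows. Statements on the series, on what has been measured and on what is new or still open speak of the compounds shown alone.

Measured so far:
compound 1 `O=C1N(CCCCCCOc2ccc(Br)cc2)CCN1c1ccncc1`: > 25000 nM
compound 2 `O=C1N(CCCCCOc2ccc(C(F)(F)F)cc2)CCN1c1ccncc1`: 12500 nM

In a functional assay on cells (Homo sapiens) for cytotoxicity (on this read-out lower numbers stand for higher toxicity in this test and higher numbers for lower toxicity in this test), compound 1 reaches only a limit, > 25000 nM, as recorded in the limit of > 25000 nM in this assay, at which 1 of the 2 values shown sits. Compound 2 gives 12500 nM in this assay. Compound 3 `O=C1N(CCCCCCCOc2ccc(Br)cc2)CCN1c1ccncc1` carries (4-bromophenoxy)methyl in place of 4-bromophenoxy on a saturated chain carbon, six bonds along the chain from an amide-type nitrogen in a ring, that is, (4-bromophenoxy)methyl in place of 4-bromophenoxy on a saturated chain carbon, six bonds along the chain from an amide-type nitrogen in a ring. Among the compounds with values here, with the sole neighbour sitting at a limit, no step beyond the scatter is expected in this assay for this lengthening. Compound 3 is expected at 30000 nM (range 12000 nM to 80000 nM). The expected step is a step that the limit leaves unreadable from compound 1 to compound 3, with a good chance that only a limit is recorded.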

Compound 3, half-maximal cytotoxic concentration: > 25000 nM
Compound 3: a limit, no number; the forecaster's own chance of this, stated with the estimate: 70%; the middle value does not contradict the limit.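

In this assay, compound 1 and compound 3 both sit at a limit, so no step can be read between them: the limit of > 25000 nM in this assay, at which 2 of the 3 values shown sit.

From the compounds shown here alone, whether (4-bromophenoxy)methyl in place of 4-bromophenoxy changes this read-out at all remains open.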